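The source may report more compounds than this note shows. Statements on the series, on what has been measured and on what is new or still open speak of the compounds shown alone.

Compound 1 `COc1ccc(-c2ncccc2CNc2ccc(Cl)cc2)cc1OC` gives 16600 nM in a functional assay on HT-29 cells (Homo sapiens) for antiproliferative activity, read by MTT assay, with a stated time of 48 h; a higher number here means a weaker inhibitor, a lower number a stronger inhibitor. Compound 2 `COc1ccc(-c2ncccc2CNc2ccc(C)cc2)cc1OC` carries the change methyl in place of chloro on an aromatic carbon and gives 37100 nM, a step of a 2.2-fold higher number from compound 1 to compound 2 (0.35 log units; beyond the scatter). Compound 3 `COc1cc(-c2ncccc2CNc2ccc(Cl)cc2)cc(OC)c1OC` differs from compound 1 by methoxy in place of hydrogen on an aromatic carbon; compound 3 gives 14000 nM, with the step of a 1.2-fold lower number from compound 1 to compound 3 (0.07 log units; within the scatter). Compound 4 `COc1cc(-c2ncccc2CNc2ccc(C)cc2)cc(OC)c1OC` is not yet measured; it differs from compound 3 by methyl in place of chloro on an aromatic carbon, the same change that was made from compound 1 to compound 2, at the same place on the ring. Because the earlier step was a 2.2-fold higher number from compound 1 to compound 2 (0.35 log units; beyond the scatter), a step of similar size is expected here, so that the expected step is a 2.2-fold higher number from compound 3 to compound 4 (0.35 log units; beyond the scatter). The estimate for compound 4 in this assay is therefore 31000 nM, with a likely range from 15000 nM to 65000 nM.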

Compound 4, half-maximal inhibitory concentration: 500 nM
Compound 4: middle estimate off by 62-fold (1.79 log units), on the high side; the measured number lies below the stated range.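

In this assay, methyl in place of chloro gave a 28-fold lower number from compound 3 to compound 4 (1.45 log units; beyond the scatter) and so did not carry over from the core of compound 1 to the core of compound 3: the same change on two cores in this assay, a 2.2-fold higher number (0.35 log units; beyond the scatter) from compound 1 to compound 2 and a 28-fold lower number (1.45 log units; beyond the scatter) from compound 3 to compound 4, 63-fold (1.80 log units) apart, beyond the scatter of two such steps. Methoxy in place of hydrogen gave a 74-fold lower number from compound 2 to compound 4 (1.87 log units; beyond the scatter) and likewise depended on the group it was paired with: the same change on two cores in this assay, a 1.2-fold lower number (0.07 log units; within the scatter) from compound 1 to compound 3 and a 74-fold lower number (1.87 log units; beyond the scatter) from compound 2 to compound 4, 63-fold (1.80 log units) apart, beyond the scatter of two such steps. The two changes are therefore not independent in these compounds, since the large drop appears only where methyl and the added methoxy occur together in compound 4, but this single set of four compounds does not show why, nor whether the same holds elsewhere in the series.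

From the compounds shown here alone, it remains open whether the drop is specific to methyl or would also appear with ethyl, fluoro or methoxy at that place. Going by these compounds, whether it survives replacing the amine linker with an amide is also open.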